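The source may report more compounds than this note shows. Statements on the series, on what has been measured and on what is new or still open speak of the compounds shown alone.

The study concerns two measured compounds and one still to be measured, all tested in a functional assay on P388 cells (Mus musculus) for inhibition; on this read-out lower numbers stand for stronger inhibition and higher numbers for weaker inhibition. Compound 1, with the structure `CC1(CO)OCC(n2cc(F)c(N)nc2=O)O1`, gives in this assay only a limit of the assay, > 100000 nM, and not a number. Compound 2, with the structure `CC1(CO)OC[C@@H](n2ccc(N)nc2=O)O1`, likewise reaches in this assay only the limit > 100000 nM, so no number is known for it. Where compound 2 stands can thus be said only in one sense: both values shown sit at the same limit, as the limit of > 100000 nM in this assay, at which 2 of the 2 values shown sit, states. The step now followed leads from compound 2 to compound 3, whose structure is `CC1(CO)OC[C@@H](n2cc(F)c(N)nc2=O)O1`; the change is fluoro in place of hydrogen on an aromatic carbon. Among the measured compounds shown here, no step between measured compounds is known, so no measured size of effect exists for this change. Compound 1 carries the same fluoro group, and its value shows only the limit as well. Compound 3 is therefore expected to stay at the limit, a step that the limit leaves unreadable from compound 2 to compound 3 being estimated because the limit of > 100000 nM in this assay, at which 2 of the 2 values shown sit, holds every value shown. The estimate for compound 3 is 150000 nM, within 50000 nM to 1000000 nM.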

Compound 3, half-maximal inhibitory concentration: > 100000 nM
Compound 3 gave a limit, no number; the forecaster's own chance of this, stated with the estimate: 85%; the middle value does not contradict the limit.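

In this assay compound 3 gives > 100000 nM, which is a limit of the assay and not a number. No step to compound 3 can be read, either from compound 2 or from compound 1, because all three compounds sit at the same limit: the limit of > 100000 nM in this assay, at which 3 of the 3 values shown sit.

The compounds shown leave open whether fluoro in place of hydrogen, or a drawn configuration, changes the inhibition in this assay at all.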